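Repeating One Aryl Swap on a Second Core

This account rests on a few compounds, and the source may have more. Where it says the series, first, only, none or still open, it means among the compounds named here.

Compound 1 `Cc1ccc(S(=O)(=O)c2nc3ccccc3nc2Nc2cccc(N)c2)cc1` is the reference point here. In a functional assay on PC-3 cells (Homo sapiens) for cytotoxicity, read by MTT assay, with a stated time of 72 h (a lower number here means a stronger inhibitor, a higher number a weaker inhibitor), compound 1 gives 2000 nM. Compound 2 `Cc1ccc(S(=O)(=O)c2nc3ccccc3nc2Nc2ccc(F)cc2)cc1` differs from it by 4-fluorophenyl in place of 3-aminophenyl on a nitrogen on an aromatic ring, and in this assay compound 2 gives 13100 nM, which amounts to a 6.6-fold higher number from compound 1 to compound 2 (0.82 log units; beyond the scatter). Compound 3 `COc1ccc(S(=O)(=O)c2nc3ccccc3nc2Nc2cccc(N)c2)cc1` carries a different core, differing from compound 1 by methoxy in place of methyl on an aromatic carbon; in this assay compound 3 gives 8600 nM, a step of a 4.3-fold higher number from compound 1 to compound 3 (0.63 log units; beyond the scatter).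

Compound 4 `COc1ccc(S(=O)(=O)c2nc3ccccc3nc2Nc2ccc(F)cc2)cc1` has not yet been measured. It differs from compound 3 by 4-fluorophenyl in place of 3-aminophenyl on a nitrogen on an aromatic ring. The place of this change, a nitrogen on an aromatic ring whose other neighbour is an aromatic carbon, is the same as in the change from compound 1 to compound 2, so this is the same change made on the other core.

The expectation rests on carrying the size of a 6.6-fold higher number from compound 1 to compound 2 (0.82 log units; beyond the scatter) over to compound 3 at 8600 nM, with some allowance for the two cores not behaving alike. For compound 4 the step is expected to be a 5.2-fold higher number from compound 3 to compound 4 (0.72 log units; beyond the scatter). Compound 4 is therefore estimated at 45000 nM, likely between 15000 nM and 150000 nM.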

Compound 4, half-maximal inhibitory concentration: 2200 nM
For compound 4 the middle estimate is 20-fold (1.31 log units) above the measured one, and the stated range ends above it.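

In this assay, the swap of 3-aminophenyl for 4-fluorophenyl does not carry over from one core to the other: with methoxy in place of methyl it gives a 3.9-fold lower number from compound 3 to compound 4 (0.59 log units; beyond the scatter), so its direction reverses, and the size and direction of the step depend on the core it is made on: the same change on two cores in this assay, a 6.6-fold higher number (0.82 log units; beyond the scatter) from compound 1 to compound 2 and a 3.9-fold lower number (0.59 log units; beyond the scatter) from compound 3 to compound 4, 26-fold (1.41 log units) apart, beyond the scatter of two such steps. The same dependence appears when the pairs are read the other way, since methoxy in place of methyl gives a 6.0-fold lower number from compound 2 to compound 4 (0.77 log units; beyond the scatter) when 4-fluorophenyl is present, the opposite direction to its step when 3-aminophenyl is present: the same change on two cores in this assay, a 4.3-fold higher number (0.63 log units; beyond the scatter) from compound 1 to compound 3 and a 6.0-fold lower number (0.77 log units; beyond the scatter) from compound 2 to compound 4, 26-fold (1.41 log units) apart, beyond the scatter of two such steps. This shows that the two changes do not add up independently in these four compounds, but it does not show why, and a single square of compounds cannot establish a rule for the wider series.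

As far as these compounds go, it remains open whether the reversal persists with ethoxy in place of methoxy or with 4-chlorophenyl in place of 4-fluorophenyl. Whether it would appear with a 3-hydroxyphenyl group on the nitrogen also remains unanswered.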